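A few compounds are considered here, and "the series" means these few. Any claim that something is new, unique, unknown or untested is made for them only; others in the source may bear on it.

Measured so far:
compound 1 `Fc1ccc(-c2csc(N/N=C/c3ccc(-n4ccnc4)cc3)n2)cc1` — 18.7%
compound 2 `Clc1ccc(-c2csc(N/N=C/c3ccc(-n4ccnc4)cc3)n2)cc1` — 32.1%
compound 3 `Fc1ccc(-c2csc(N/N=C/c3ccc(-n4cncn4)cc3)n2)cc1` — 35.9%

In an ADME assay on THP-1 cells (Homo sapiens) for cytotoxicity, read by MTT assay, tested at 50 ug/mL (on this read-out higher numbers stand for more inhibition at the one concentration tested (going by the name of the read-out) and lower numbers for less inhibition), compound 1 gives 18.7%, compound 2 gives 32.1% and compound 3 gives 35.9%. Compound 2 differs from compound 1 by one change, (chloro in place of fluoro on an aromatic carbon), and this produced a number 13.4 percentage points higher from compound 1 to compound 2 (beyond the scatter). The two cores differ in another way, (1H-1,2,4-triazol-1-yl in place of 1H-imidazol-1-yl on an aromatic carbon), which gave a number 17.2 percentage points higher from compound 1 to compound 3 (beyond the scatter). Compound 4 `Clc1ccc(-c2csc(N/N=C/c3ccc(-n4cncn4)cc3)n2)cc1` is not yet measured. It differs from compound 3 by chloro in place of fluoro on an aromatic carbon, the same change seen between compound 1 and compound 2, made on the core of compound 3. If that change acts similarly here, a step of about a number 11.1 percentage points higher from compound 3 to compound 4 (beyond the scatter) is expected from compound 3 to compound 4 in this assay, resting on the single earlier example a number 13.4 percentage points higher from compound 1 to compound 2 (beyond the scatter). Compound 4 is therefore estimated at 47%, with a range from 32% to 62%.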

Compound 4, a percentage reported as inhibition, at one concentration (the size of the read-out at that concentration, not a potency): 28.4%
The estimate for compound 4 lay 18.6 percentage points above the measured number; the measured number lies below the stated range.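

In this assay, chloro in place of fluoro on the core of compound 3 gave a number 7.5 percentage points lower from compound 3 to compound 4 (within the scatter), so the rise seen on the core of compound 1 did not carry over: the same change on two cores in this assay, a number 13.4 percentage points higher (beyond the scatter) from compound 1 to compound 2 and a number 7.5 percentage points lower (within the scatter) from compound 3 to compound 4, 20.9 percentage points apart, beyond the scatter of two such steps.
Likewise, 1H-1,2,4-triazol-1-yl in place of 1H-imidazol-1-yl gave a number 3.7 percentage points lower from compound 2 to compound 4 (within the scatter), so that change also depends on the core it is made on: the same change on two cores in this assay, a number 17.2 percentage points higher (beyond the scatter) from compound 1 to compound 3 and a number 3.7 percentage points lower (within the scatter) from compound 2 to compound 4, 20.9 percentage points apart, beyond the scatter of two such steps.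
These four compounds show that neither step can simply be transferred between these cores, but they do not show why the steps differ or how either change would behave on a further core.

The compounds shown leave open what a methoxy group or an amine would do on the same aromatic carbon in place of fluoro or chloro.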